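This account rests on a few compounds, and the source may have more. Where it says the series, first, only, none or still open, it means among the compounds named here.

Of the compounds shown here, three have been measured in a functional assay on HEK293 cells for antagonist activity at thromboxane A2 receptor (Homo sapiens), read by fluorescence and calcium flux; on this read-out higher numbers stand for weaker inhibition and lower numbers for stronger inhibition. Compound 1 `Cc1ccccc1Oc1ccc(C#N)cc1S(=O)(=O)NC(=O)NC(C)(C)C` gives 3690 nM in this assay, and compound 2 `CC(C)(C)NC(=O)NS(=O)(=O)c1cc(C#N)ccc1Oc1ccc(F)cc1` gives 4350 nM; the step of a 1.2-fold higher number from compound 1 to compound 2 (0.07 log units; within the scatter) lies within the scatter of repeated measurements. Among the measured compounds shown here, compound 3 `CC(C)NC(=O)NS(=O)(=O)c1cc(C#N)ccc1Oc1ccc(Cl)cc1` gives 9460 nM, the highest of the three numbers, and its gaps to compound 2 and to compound 1 both lie beyond the scatter, so compound 3 is the weakest inhibitor of the three so far.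

Compound 4 `CC(C)(C)NC(=O)NS(=O)(=O)c1cc(C#N)ccc1Oc1ccc(Cl)cc1` has not yet been measured. It differs from compound 3 in one place: methyl in place of hydrogen on a saturated chain carbon bound to an amide-type nitrogen and two saturated chain carbons. For the measured compounds named here, no measured pair shows exactly this change; the only single-point step measured, between compound 1 and compound 2, exchanges 2-methylphenyl for 4-fluorophenyl on an oxygen on an aromatic ring and leaves the chain untouched. What compound 1 and compound 2 do show is that both carry tert-butyl and give numbers close to each other and well below the number of compound 3, which carries isopropyl and shares with compound 4 the group on the oxygen. Compound 4 is therefore expected to move toward those two values by a step of about a 2.1-fold lower number from compound 3 to compound 4 (0.32 log units; beyond the scatter), giving an estimated 4500 nM with a range from 2000 nM to 10000 nM.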

Compound 4, half-maximal inhibitory concentration: 5640 nM
Compound 4: the middle estimate sits 1.3-fold (0.10 log units) below what was measured, and the stated range covers the measured number.
By their numbers in this assay, from the lowest: compounds 1, 2, 4 and 3 (each within the scatter of the next, the first and the last beyond it).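

The step from isopropyl to tert-butyl on the chain carbon bound to the amide-type nitrogen can now be read directly in this assay as a 1.7-fold lower number from compound 3 to compound 4 (0.22 log units; within the scatter) and so stays within what repeat measurements would give; the added methyl, on its own, therefore produces no clear change here. With tert-butyl held fixed, swapping the group on the oxygen makes little difference either, since chloro in place of fluoro gives a 1.3-fold higher number from compound 2 to compound 4 (0.11 log units; within the scatter) and 4-chlorophenyl in place of 2-methylphenyl gives a 1.5-fold higher number from compound 1 to compound 4 (0.18 log units; within the scatter) and so all three tert-butyl compounds stand level within the scatter. Nothing beyond these inhibition numbers is available to explain them.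

Isopropyl appears only alongside 4-chlorophenyl, so it remains open whether the same small step would hold with 4-fluorophenyl or 2-methylphenyl on the oxygen. It is also open how this assay would respond to a different group on that nitrogen, such as ethyl, a longer chain like n-butyl, or a cyclohexyl ring, since the two groups shown differ by only a single methyl.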